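A Chloro-to-Hydrogen Step Tried on a Second Core

This account rests on a few compounds, and the source may have more. Where it says the series, first, only, none or still open, it means among the compounds named here.

Compound 1 `ClCc1ccccc1Cn1cnc2c(Cl)nc(Cl)nc21` and compound 2 `ClCc1ccccc1Cn1cnc2c(Cl)ncnc21` share one core and differ in a single place, (hydrogen in place of chloro on an aromatic carbon). In a functional assay on UACC-62 cells (Homo sapiens) for cytotoxicity, read by sulforhodamine B assay, with a stated time of 48 h (on this read-out higher numbers stand for lower toxicity in this test and lower numbers for higher toxicity in this test), compound 1 gives 5240 nM, while compound 2 gives 28200 nM, so that the step is a 5.4-fold higher number from compound 1 to compound 2 (0.73 log units; beyond the scatter).

Compound 3 `ClCc1ccc(Cn2cnc3nc(Cl)nc(Cl)c32)cc1` is built from the same atoms as compound 1, joined differently; the difference between the two cores is not broken down here. In this assay compound 3 gives 6020 nM. Against compound 1 this number lies within the scatter, so the two cannot be ordered. Against compound 2 the number for compound 3 is lower, by a margin beyond the scatter.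

Compound 4 `ClCc1ccc(Cn2cnc3ncnc(Cl)c32)cc1` carries the same change on the core of compound 3 that compound 2 carries on the core of compound 1, namely (hydrogen in place of chloro on an aromatic carbon). The surroundings of the place are described in the same words for both pairs, so this is the same change rather than merely the same kind. Among the measured compounds shown here, the expectation for compound 4 therefore rests on the single earlier instance, compound 1 to compound 2, whose step was a 5.4-fold higher number from compound 1 to compound 2 (0.73 log units; beyond the scatter). On that basis, compound 4 is expected to move from compound 3 by a 5.3-fold higher number from compound 3 to compound 4 (0.73 log units; beyond the scatter). In this assay compound 4 is estimated at 32000 nM, with a likely range from 14000 nM to 70000 nM. Whether a second core carries the step faithfully is exactly what the measurement of compound 4 will tell.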

Compound 4, concentration lethal to 50% of the cells: 34700 nM
The estimate for compound 4 lay 1.1-fold (0.04 log units) below the measured number; the range from low to high includes it.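

In this assay the second core answers as the first did: hydrogen in place of chloro on an aromatic carbon gives a 5.8-fold higher number from compound 3 to compound 4 (0.76 log units; beyond the scatter), a move towards lower toxicity in this test. Set beside the earlier step, the change carries from one core to the other with its size preserved, and the two steps cannot be told apart: the same change on two cores in this assay, a 5.4-fold higher number (0.73 log units; beyond the scatter) from compound 1 to compound 2 and a 5.8-fold higher number (0.76 log units; beyond the scatter) from compound 3 to compound 4, 1.1-fold (0.03 log units) apart, within the scatter of two such steps This is agreement between only two pairs, at one place on the ring, in a single cell line and with a single read-out, so it shows that the step held on these two cores but does not show that it would hold on any other core or in any other test.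

The compounds shown leave open what a different group on this same aromatic carbon, between two ring nitrogen atoms, would do, for instance an amine or a methoxy group in place of the chloro, and whether either would land nearer to the chloro compounds or to the hydrogen compounds. They also leave open whether the other chloro group on the ring could be exchanged for such an amine with a step of similar size on both cores.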